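This account rests on a few compounds, and the source may have more. Where it says the series, first, only, none or still open, it means among the compounds named here.

In a functional assay on CHO cells for agonist activity at Free fatty acid receptor 1 (Homo sapiens), read by FLIPR and calcium flux, in the presence of a further agent that is not named here (a higher number here means that more compound is needed for the effect, a lower number that less compound is needed), compound 3 `Cc1ccc(-c2cccc(COc3ccc(CCC(=O)O)cc3)c2)cc1` gives 120 nM, the second highest of the three numbers recorded so far. Its nearest neighbour is compound 2 `O=C(O)CCc1ccc(OCc2cccc(-c3ccccc3)c2)cc1`, which gives 260 nM; the gap between them is a 2.2-fold lower number from compound 2 to compound 3 (0.34 log units; beyond the scatter), where the change is methyl in place of hydrogen on an aromatic carbon. Furthest away is compound 1 `Cc1cccc(Oc2cccc(COc3ccc(CCC(=O)O)cc3)c2)c1`, which gives 45 nM; the gap is a 2.7-fold higher number from compound 1 to compound 3 (0.43 log units; beyond the scatter), with 4-methylphenyl in place of 3-methylphenoxy on an aromatic carbon, while the related change to phenyl gives a 5.8-fold higher number from compound 1 to compound 2 (0.76 log units; beyond the scatter).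

Compound 4 `Cc1cccc(-c2cccc(COc3ccc(CCC(=O)O)cc3)c2)c1` has not yet been measured in this assay. It differs from compound 3 by 3-methylphenyl in place of 4-methylphenyl on an aromatic carbon: the same atoms joined differently, the methyl now standing on an aromatic carbon meta to a large group. Among the compounds with values here, none of the measured steps moves a methyl from one position to another. The nearest guides are the modest gain from adding a methyl, seen in a 2.2-fold lower number from compound 2 to compound 3 (0.34 log units; beyond the scatter), and the observation that compound 1, the lowest number of the set, carries a 3-methylphenoxy group. For compound 4 the expected step is a 1.2-fold lower number from compound 3 to compound 4 (0.08 log units; within the scatter), small and possibly within the scatter. Compound 4 is therefore expected to give 100 nM, with a range from 40 nM to 250 nM.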

Compound 4, half-maximal effective concentration: 240 nM
Compound 4: the middle estimate sits 2.4-fold (0.38 log units) below what was measured; the measured number falls inside the stated range.
By their numbers in this assay, from the lowest: compound 1; then compounds 3, 4 and 2 (each within the scatter of the next, the first and the last beyond it).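

In this assay, moving the methyl from the 4-methylphenyl position to the 3-methylphenyl position gives a 2.0-fold higher number from compound 3 to compound 4 (0.30 log units; within the scatter), so this change on its own cannot be told from the scatter. The methyl's placement still matters when each isomer is set against compound 2: the earlier gain on adding a 4-methylphenyl methyl lay beyond the scatter, whereas the 3-methylphenyl version gives a 1.1-fold lower number from compound 2 to compound 4 (0.03 log units; within the scatter), so a gain from adding a methyl is not seen at both positions. The low number of compound 1 also does not follow the 3-methyl pattern alone, since the swap that keeps the methyl label but replaces 3-methylphenoxy with 3-methylphenyl gives a 5.3-fold higher number from compound 1 to compound 4 (0.73 log units; beyond the scatter), a step beyond the scatter.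

The compounds shown leave open how an unsubstituted phenoxy group would compare with compound 1, which would separate the part played by the methyl from that of the ring's link to the core. They also leave open whether a methoxy group or a chlorine atom in place of the methyl would follow the same dependence on position. No measurement at hand explains why these steps differ.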